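Methoxy for amino on a sulfonamide core in cells

The source may hold more compounds than are shown below. What is called first, only, known or untested is meant among the compounds shown, and "the series" means these compounds.

The study concerns a set of sulfonamides built on a shared core and examined in an ADME assay on HCT-116 cells (Homo sapiens) for cytotoxicity, read by CellTiter-Glo, with a stated time of 72 h; on this read-out lower numbers stand for stronger inhibition and higher numbers for weaker inhibition. Compound 1 `CC1CCN(C2CCN(S(=O)(=O)c3cccc(N)c3)CC2)CC1` carries an amino group on its aromatic ring. In this assay compound 1 returns only a limit, > 5000 nM, and not a number. Compound 2 `CC1CCN(C2CCN(S(=O)(=O)c3ccccc3-c3ccc(C(F)(F)F)cc3)CC2)CC1` likewise gives this assay only a limit, > 5000 nM. Compound 3 `CC1CCN(C2CCN(S(=O)(=O)c3ccc(-c4ccc(Cl)cc4)cc3)CC2)CC1` also reaches only a limit in this assay, > 5000 nM. Every value shown so far is therefore a limit, as captured by the observation that (the limit of > 5000 nM in this assay, at which 3 of the 3 values shown sit), and compound 1 stands nowhere apart from the other two: no number separates them.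

Compound 4 `COc1cccc(S(=O)(=O)N2CCC(N3CCC(C)CC3)CC2)c1` has not yet been measured in this assay. It differs from compound 1 in one place (methoxy in place of amino on an aromatic carbon). Within the data shown here, no step between measured compounds exists to lean on, so the three limits are the only guide. The step expected here, a step that the limit leaves unreadable from compound 1 to compound 4, is estimated to stay within the scatter rather than to move in either direction, and compound 4 is accordingly expected to give this assay a limit as well. Compound 4 is estimated at 8000 nM, with a range from 4000 nM to 20000 nM.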

Compound 4, half-maximal inhibitory concentration: > 5000 nM
Compound 4: a limit, no number (the forecaster's own chance of this, stated with the estimate: 80%); the middle value does not contradict the limit.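

In this assay, among these compounds, compound 4 returns only a limit and not a number, as compound 1 does, so no step between compound 1 and compound 4 can be read: the limit of > 5000 nM in this assay, at which 4 of the 4 values shown sit. The compounds shown leave open whether methoxy and amino on the shared core differ at all in this assay, since no compound here yields a number.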